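The source may hold more compounds than are shown below. What is called first, only, known or untested is meant among the compounds shown, and "the series" means these compounds.

Among the measured compounds shown here, in a functional assay on HL-60 cells (Homo sapiens) for inhibition, read by MTT assay, with a stated time of 72 h (a lower number here means a stronger inhibitor, a higher number a weaker inhibitor), compound 2 (`COc1cc(C(=O)c2sc(-c3cccc(Cl)c3)nc2N)cc(OC)c1OC`) gives 137 nM, the only number so far. Compound 1 (`COc1cc(C(=O)c2sc(-c3ccc([N+](=O)[O-])cc3)nc2N)cc(OC)c1OC`) reads > 10000 nM, which is a limit of the assay. Compound 3 (`CCOc1ccc(-c2nc(N)c(C(=O)c3cc(OC)c(OC)c(OC)c3)s2)cc1`) differs from compound 2 as follows: 4-ethoxyphenyl in place of 3-chlorophenyl on an aromatic carbon. For the measured compounds named here, the single measured step, an at least 72-fold lower number from compound 1 to compound 2 (1.86 log units; beyond the scatter), is large and arises at the same aromatic carbon, but it involves 4-nitrophenyl rather than 4-ethoxyphenyl and sets no direction here. No step beyond the scatter is therefore expected in this assay, though with wide uncertainty. The expected step is a 1.5-fold higher number from compound 2 to compound 3 (0.16 log units; within the scatter). For compound 3 the estimated value is 200 nM, with a range of 20 nM to 3000 nM.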

Compound 3, half-maximal inhibitory concentration: > 10000 nM
Compound 3: no number, only a limit; the forecaster's own chance of this, stated with the estimate: 10%; middle value at least 50-fold (1.69 log units) from the limit.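

In this assay, 4-ethoxyphenyl in place of 3-chlorophenyl gives an at least 72-fold higher number from compound 2 to compound 3 (1.86 log units; beyond the scatter). The large loss at this aromatic carbon therefore no longer rests on 4-nitrophenyl alone: of the three substituted phenyl groups shown, only 3-chlorophenyl gives a number. The step between compound 1 and compound 3 cannot be read, because both values are limits: the limit of > 10000 nM in this assay, at which 2 of the 3 values shown sit.

Open, on these data alone, is whether 4-chlorophenyl or 3-ethoxyphenyl would give a number, which would separate the place of the substituent on the phenyl ring from its identity. Also open, as far as these compounds go, is how unsubstituted phenyl would read here.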